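The source may hold more compounds than are shown below. What is called first, only, known or untested is meant among the compounds shown, and "the series" means these compounds.

Working notes on the series. Compound 3 `c1cn2cc(-c3ccsc3)nc(-c3ccc4ncn(C5CCCCC5)c4c3)c2n1` is second highest of the three numbers in a functional assay on HL-60 cells (Homo sapiens) for inhibition, read by sulforhodamine B assay, with a stated time of 48 h, tested at 10 uM (a higher number here means more inhibition at the concentration tested (going by the name of the read-out), a lower number less inhibition), at 18.5%. Its nearest neighbour is compound 1 `Brc1cn2ccnc2c(-c2ccc3ncn(C4CCCCC4)c3c2)n1`, which gives 18%, a gap within the scatter; the furthest is compound 2 `COc1ccc(-c2cn3ccnc3c(-c3ccc4ncn(C5CCCCC5)c4c3)n2)cc1`, which gives 98.6%, the step being a number 80.1 percentage points lower from compound 2 to compound 3 (beyond the scatter). Compound 4 `Fc1ccccc1-c1cn2ccnc2c(-c2ccc3ncn(C4CCCCC4)c3c2)n1` is the next case: 2-fluorophenyl in place of thiophen-3-yl on an aromatic carbon. For the measured compounds named here, two steps bear on it. Replacing bromo with 4-methoxyphenyl gave a number 80.6 percentage points higher from compound 1 to compound 2 (beyond the scatter), while replacing bromo with thiophen-3-yl gave a number 0.5 percentage points higher from compound 1 to compound 3 (within the scatter). A six-membered aromatic ring of carbon only is therefore expected to raise inhibition, though a single example supports this. The expected step is a number 41.5 percentage points higher from compound 3 to compound 4 (beyond the scatter). Compound 4 is estimated at 60%, within 15% to 99%.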

Compound 4, a percentage reported as inhibition, at one concentration (the size of the read-out at that concentration, not a potency): 9.3%
For compound 4 the middle estimate is 50.7 percentage points above the measured one; measured number below the stated range.
By their numbers in this assay, from the lowest: compounds 4, 1 and 3 (each within the scatter of the next); then compound 2.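

Replacing 4-methoxyphenyl with 2-fluorophenyl gives a number 89.3 percentage points lower from compound 2 to compound 4 (beyond the scatter) in this assay and so a six-membered aromatic ring of carbon only does not by itself carry the high number at this position. The same group gives a number 9.2 percentage points lower from compound 3 to compound 4 (within the scatter) against thiophen-3-yl and a number 8.7 percentage points lower from compound 1 to compound 4 (within the scatter) against bromo and so 4-methoxyphenyl remains the only group shown that stands apart. No measurement at hand accounts for the gap between the two substituted phenyl groups.

Still open, as far as these compounds go, is whether the high number depends on the methoxy group, on where it sits on the ring, or on the absence of fluorine. Plain phenyl, 4-fluorophenyl and 2-methoxyphenyl at this position would separate these readings.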